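A few compounds are considered here, and "the series" means these few. Any claim that something is new, unique, unknown or untested is made for them only; others in the source may bear on it.

Three compounds built on one shared core have been examined in a functional assay for agonist activity at Alpha-1A adrenergic receptor (Homo sapiens); a higher number here means a larger maximal response, a lower number a smaller maximal response. Compound 1 `CSc1ccc(C)cc1NCC1=NCCN1` gives 101%. Compound 2 `CS(=O)(=O)c1ccc(F)cc1NCC1=NCCN1` gives 96%. Compound 3 `Cc1ccc(S(C)(=O)=O)c(NCC2=NCCN2)c1` gives 98%. All three numbers lie within the scatter of one another, so none of them can be set apart as a stronger or weaker agonist on this evidence.

Two of the pairs differ in a single place. Between compound 3 and compound 1 the change is methylsulfanyl in place of methylsulfonyl on an aromatic carbon, and it brought a number 3 percentage points higher from compound 3 to compound 1 (within the scatter). Between compound 3 and compound 2 the cores differ by fluoro in place of methyl on an aromatic carbon, and the step measured was a number 2 percentage points higher from compound 2 to compound 3 (within the scatter). Neither change moved the largest response beyond what repeated measurements of this kind would show anyway.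

Compound 4 `CSc1ccc(F)cc1NCC1=NCCN1` has not yet been measured. It is reached from compound 2 by methylsulfanyl in place of methylsulfonyl on an aromatic carbon. Among the measured compounds shown here, this is the same kind of change as the one from compound 3 to compound 1, but not the same: in compound 4 the group that enters sits para to a fluoro group, whereas in compound 1 it sits para to a methyl group. For the measured compounds named here, for compound 4 the step from compound 2 is expected to be a number 3 percentage points higher from compound 2 to compound 4 (within the scatter) because a number 3 percentage points higher from compound 3 to compound 1 (within the scatter) is the one earlier instance of this kind of change and it gave a result within the scatter. Compound 4 is therefore estimated to reach 99%, with a range from 88% to 108%.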

Compound 4, largest response reached (reported as maximum), in percent of the reference or control that the assay uses: 90%
For compound 4 the middle estimate is 9 percentage points above the measured one; the measured number falls inside the stated range.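

In this assay, methylsulfanyl in place of methylsulfonyl on the core carrying the fluoro group gave a number 6 percentage points lower from compound 2 to compound 4 (within the scatter), and this step does not differ from the earlier instance of the same change: the same change on two cores in this assay, a number 3 percentage points higher (within the scatter) from compound 3 to compound 1 and a number 6 percentage points lower (within the scatter) from compound 2 to compound 4, 9 percentage points apart, within the scatter of two such steps. Fluoro in place of methyl gave a number 11 percentage points lower from compound 1 to compound 4 (beyond the scatter), the only one of the new steps that passes the scatter, yet it too does not stand apart from its earlier counterpart: the same change on two cores in this assay, a number 2 percentage points higher (within the scatter) from compound 2 to compound 3 and a number 11 percentage points higher (beyond the scatter) from compound 4 to compound 1, 9 percentage points apart, within the scatter of two such steps. These comparisons therefore give no sign that either change behaves differently from one core to the other, but they do not prove that either change carries over unaltered, as each rests on just two steps and both draw on the same four compounds.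

The compounds shown leave open whether the largest response would hold with an amine, a carboxylic acid or a longer alkyl chain in the place taken by methylsulfanyl and methylsulfonyl. They also leave open what chloro or methoxy would do in the place taken by fluoro and methyl, and whether the two changes would behave alike on a core bearing either of those groups.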